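This account rests on a few compounds, and the source may have more. Where it says the series, first, only, none or still open, it means among the compounds named here.

Three compounds have been measured in an in vitro assay on HEK385-7 cells for displacement of a labelled ligand from prostaglandin D2 receptor 2 (Homo sapiens); a higher number here means a weaker inhibitor, a lower number a stronger inhibitor:

Compound 1, `O=C(O)Cc1sc(C(c2ccccc2)c2ccccc2)nc1-c1ccccc1`, gives 570 nM.
Compound 2, `O=C(O)Cc1sc(C(c2ccccc2)c2ccccc2)nc1-c1cccc(F)c1`, gives 2.9 nM.
Compound 3, `O=C(O)Cc1sc(C(c2ccccc2)c2ccccc2)nc1-c1ccc(C(F)(F)F)cc1`, gives 1100 nM.

Compound 3 has the highest number of the three in this assay. Its nearest neighbour is compound 1, with a 1.9-fold higher number from compound 1 to compound 3 (0.29 log units; within the scatter). Its furthest is compound 2, with a 380-fold higher number from compound 2 to compound 3 (2.58 log units; beyond the scatter).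

The next compound, compound 4, is `COc1ccc(OC)c(-c2nc(C(c3ccccc3)c3ccccc3)sc2CC(=O)O)c1`. The change from compound 3 is 2,5-dimethoxyphenyl in place of 4-(trifluoromethyl)phenyl on an aromatic carbon.

Among the compounds with values here, two measured steps bear on this change. The first is the removal of the trifluoromethyl group, a 1.9-fold higher number from compound 1 to compound 3 (0.29 log units; within the scatter), so taking it away again is not expected to move the number much on its own. Within the data shown here, the second is the only measured step that adds a substituent to that ring, a 200-fold lower number from compound 1 to compound 2 (2.29 log units; beyond the scatter), which shows that a single small substituent on this phenyl ring can shift the number greatly. Among the measured compounds shown here, no measured compound carries a methoxy group, so the direction for compound 4 is not anchored; the one large step known points downward. The step from compound 3 to compound 4 is therefore expected to be a 3.7-fold lower number from compound 3 to compound 4 (0.56 log units; beyond the scatter), with wide uncertainty. Compound 4 is estimated at 300 nM, in a range from 20 nM to 3000 nM.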

Compound 4, half-maximal inhibitory concentration: > 105 nM
Compound 4: only a limit was reported (the forecaster's own chance of this, stated with the estimate: 5%); the middle value lies beyond the limit too.
By their numbers in this assay, from the lowest: compound 2; then compounds 1 and 3 (each within the scatter of the next).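

For compound 4, this assay gives no number but only a limit, the one such result among the compounds shown: the limit of > 105 nM in this assay, at which 1 of the 4 values shown sits. Even so, this limit is enough to separate compound 4 from compound 2, with an at least 36-fold higher number from compound 2 to compound 4 (1.55 log units; beyond the scatter), so a 2,5-dimethoxyphenyl group on the aromatic carbon next to the ring nitrogen does not keep the low number seen with 3-fluorophenyl, and compound 2 remains the only compound here whose number stands clearly apart from all the others. The steps that link compound 4 to compound 1 and to compound 3 cannot be read from the limit, so compound 4 cannot be placed relative to either of them, and the effect of this change on the unsubstituted phenyl or the 4-(trifluoromethyl)phenyl compound remains undefined.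

What the compounds shown leave open is whether a single methoxy group on this phenyl ring would behave as the pair in compound 4 does. They also leave open whether the low number of compound 2 is particular to fluorine or would also appear with a chlorine atom, a methyl group or a nitrile on the ring.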